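The compounds below may be only part of what the source reports. "The series", "measured", "known", "first", "only" and "open" are said of these compounds alone.

The series shares the core seen in compound 1 `O=C(CCCCCc1nc2ccccc2[nH]1)NO`, which in a functional assay on SK-OV-3 cells (Homo sapiens) for cytotoxicity (a higher number here means a weaker inhibitor, a lower number a stronger inhibitor), gives 11000 nM. Compound 2 `O=C(CCCCCCc1nc2ccc(-c3cccc(F)c3)cc2[nH]1)NO` gives 1500 nM in this assay, the lowest of the two numbers shown; compound 1 is the nearest, with a higher number, beyond the scatter. Compound 3 `CN(C)c1ccc2nc(CCCCCCC(=O)NO)[nH]c2c1` has not yet been measured in this assay; it differs from compound 2 in one place: dimethylamino in place of 3-fluorophenyl on an aromatic carbon. Going by the values given here, no step between measured compounds is available for this change, so the expectation rests on the two values alone: a weakening is expected, a 3.0-fold higher number from compound 2 to compound 3 (0.48 log units; beyond the scatter), beyond the scatter. Compound 3 is expected to give about 4500 nM in this assay, within 1500 nM to 13000 nM.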

Compound 3, half-maximal inhibitory concentration: 1200 nM
Compound 3: the middle estimate sits 3.8-fold (0.57 log units) above what was measured, and the stated range ends above it.
By their numbers in this assay, from the lowest: compounds 3 and 2 (each within the scatter of the next); then compound 1.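

Putting dimethylamino in place of 3-fluorophenyl on this aromatic carbon gives a 1.3-fold lower number from compound 2 to compound 3 (0.10 log units; within the scatter) in this assay, so the two groups cannot be told apart in this assay. The position therefore tolerates the loss of the six-membered aromatic ring and a drop in heavy atoms, with a hydrogen-bond acceptor entering, without a step beyond the scatter. No available evidence accounts for this parity.

Open, as far as these compounds go, is whether a carboxylic acid or a primary amine on this carbon would stay at the level of compound 2 and compound 3. From the compounds shown here alone, a plain hydrogen there is equally open.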